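The source may report more compounds than this note shows. Statements on the series, on what has been measured and on what is new or still open speak of the compounds shown alone.

Measured so far:
compound 1, `O=[N+]([O-])c1ccc(-c2nc3cc(C(F)(F)F)ccc3[nH]2)c([N+](=O)[O-])c1`: in an ADME assay on BHK cells (Mesocricetus auratus) for cytotoxicity, read by MTT assay, with a stated time of 96 h (on this read-out higher numbers stand for lower toxicity in this test and lower numbers for higher toxicity in this test), compound 1 gives 8000 nM.
compound 2, `O=[N+]([O-])c1ccc(-c2nc3ccccc3[nH]2)c([N+](=O)[O-])c1`: in this assay compound 2 gives > 100000 nM, which is a limit of the assay and not a number.

Compound 2 thus stands at the upper edge of the numbers shown, above compound 1. Within the data shown here, the only measured step, an at least 12-fold higher number from compound 1 to compound 2 (1.09 log units; beyond the scatter), runs into (the limit of > 100000 nM in this assay, at which 1 of the 2 values shown sits). Compound 3, `O=[N+]([O-])c1ccccc1-c1nc2ccccc2[nH]1`, is not yet measured; against compound 2 the change is hydrogen in place of nitro on an aromatic carbon. Among the measured compounds shown here, no measured step removes a nitro group, so the step from compound 1 to compound 2 bears on this only by placing the core without trifluoromethyl at the limit. No step beyond the scatter is expected in this assay. Compound 3 is expected at 100000 nM, range 30000 nM to 300000 nM. The expected step is a number no higher from compound 2 to compound 3 (the limit leaves the size open).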

Compound 3, half-maximal cytotoxic concentration: > 100000 nM
Compound 3 was reported as a limit (the forecaster's own chance of this, stated with the estimate: 70%); the middle value sits exactly at the limit.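

Among these compounds, compound 2 and compound 3 both stand as limits and not as numbers in this assay, so no step between them can be read: the limit of > 100000 nM in this assay, at which 2 of the 3 values shown sit.
The compounds shown leave open whether hydrogen in place of nitro changes the cytotoxic concentration at all.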